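The compounds below may be only part of what the source reports. "The series", "measured", "known", "first", "only" and "open" are said of these compounds alone.

Going by the values given here, in a functional assay on NCI-H460 cells (Homo sapiens) for cytotoxicity, read by MTT assay, with a stated time of 72 h (a higher number here means a weaker inhibitor, a lower number a stronger inhibitor), compound 1 `CC(S)C(=O)N[C@@H](C)C(=O)O` gives 18400000 nM, while compound 2 `CC(S)C(=O)N[C@H](C(=O)O)C(C)C` gives 6330000 nM, the lowest number so far. Compound 3 `CC(S)C(=O)N[C@@H](CO)C(=O)O` carries hydroxymethyl in place of isopropyl on a saturated chain carbon bound to an amide-type nitrogen and a carbonyl carbon. Among the compounds with values here, only one measured step bears on this place: a 2.9-fold lower number from compound 1 to compound 2 (0.46 log units; beyond the scatter), a modest change that brought isopropyl in place of methyl. With isopropyl leaving again, a modest move to a higher number is expected in this assay, an estimated 2.4-fold higher number from compound 2 to compound 3 (0.37 log units; beyond the scatter). For compound 3 the estimated value is 15000000 nM, with an expected range from 6000000 nM to 35000000 nM.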

Compound 3, half-maximal inhibitory concentration: > 20000000 nM
Compound 3: a limit, no number (the forecaster's own chance of this, stated with the estimate: 5%); at least 1.3-fold (0.12 log units) between middle value and limit.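

In this assay compound 3 gives only a limit of the assay, not a number: the limit of > 20000000 nM in this assay, at which 1 of the 3 values shown sits. At this saturated chain carbon, hydroxymethyl loses the lower number that isopropyl brought, with an at least 3.1-fold higher number from compound 2 to compound 3 (0.49 log units; beyond the scatter). Set against methyl, the reading is an at least 1.0-fold higher number from compound 1 to compound 3 (0.03 log units; that floor lies within the scatter), so the data do not separate hydroxymethyl from methyl here.

Going by these compounds, how far the true value of compound 3 lies past its limit stays open. So does whether an amine, a carboxylic acid or a longer chain on this carbon would give a lower number than isopropyl.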